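The source may hold more compounds than are shown below. What is called first, only, known or untested is meant among the compounds shown, and "the series" means these compounds.

Of the compounds shown here, two sharing one core have been tested so far in a functional assay on BT-549 cells (Homo sapiens) for inhibition; a lower number here means a stronger inhibitor of growth, a higher number a weaker inhibitor of growth. Compound 1 `COc1cc(/C=C/c2ccc(S(N)(=O)=O)cc2)cc(OC)c1` gives 10700 nM, and compound 2 `NS(=O)(=O)c1ccc(/C=C/c2ccc(O)c(O)c2)cc1` gives 4130 nM. Compound 1 therefore holds the higher of the two numbers, making it the weaker inhibitor of growth, and its gap to compound 2 lies beyond the usual scatter.

Compound 3 `COc1cccc(/C=C/c2ccc(S(N)(=O)=O)cc2)c1` has not yet been measured. It comes from compound 1 through a single edit: hydrogen in place of methoxy on an aromatic carbon. A methoxy group remains on that ring, meta to the new hydrogen. Among the compounds with values here, compound 2 differs from compound 1 in more than one place, so no measured pair shows what this single edit does. The expectation therefore stays close to compound 1, with no step beyond the scatter in either direction. The expected change, a 1.3-fold lower number from compound 1 to compound 3 (0.13 log units; within the scatter), is only an estimate and could prove wrong. In this assay the estimated value for compound 3 is 8000 nM, with an expected range from 3000 nM to 22000 nM.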

Compound 3, concentration for 50% growth inhibition: 6380 nM
The estimate for compound 3 lay 1.3-fold (0.10 log units) above the measured number; measured number inside the range.
By their numbers in this assay, from the lowest: compounds 2, 3 and 1 (each within the scatter of the next, the first and the last beyond it).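

Placing hydrogen on this aromatic carbon in place of methoxy gives, in this assay, a 1.7-fold lower number from compound 1 to compound 3 (0.22 log units; within the scatter). Within the data shown here, this is the first direct reading of this single edit, and it places compound 1 and compound 3 within the scatter of each other, so the two cannot be told apart as inhibitors of growth. At this position, then, this methoxy group can give way to hydrogen without a change that the assay can distinguish from scatter, and no available evidence explains this result.

What the compounds shown leave open is whether a different group on this carbon, such as an amine, a carboxylic acid or a fluorine atom, would shift the number beyond the scatter in either direction. Also open, going by these compounds, is what would happen if the remaining methoxy group of compound 3 gave way to hydrogen as well, a second step that could show whether this ring needs any methoxy group at all.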